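A Third Methyl Placement on the Core of Compound 1

A few compounds are considered here, and "the series" means these few. Any claim that something is new, unique, unknown or untested is made for them only; others in the source may bear on it.

Compound 1 `Oc1cc(-c2ccc3ccccc3c2)nc2ncccc12` is the parent of this small set. Among the measured compounds shown here, in a functional assay on SF-295 cells (Homo sapiens) for antiproliferative activity (on this read-out higher numbers stand for weaker inhibition of growth and lower numbers for stronger inhibition of growth), compound 1 gives 9120 nM, the highest of the three numbers measured so far. Two relatives carry a methyl in place of hydrogen on an aromatic carbon at different positions of the shared core. Compound 2 `Cc1ccnc2nc(-c3ccc4ccccc4c3)cc(O)c12` gives 1480 nM in this assay, and compound 3 `Cc1ccc2c(O)cc(-c3ccc4ccccc4c3)nc2n1` gives 3800 nM. The two steps from the parent are both beyond the scatter: a 6.2-fold lower number from compound 1 to compound 2 (0.79 log units; beyond the scatter) and a 2.4-fold lower number from compound 1 to compound 3 (0.38 log units; beyond the scatter). Both are modest, and both run toward stronger inhibition of growth.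

Compound 4 `Cc1cnc2nc(-c3ccc4ccccc4c3)cc(O)c2c1` differs from compound 1 as follows: methyl in place of hydrogen on an aromatic carbon. It is thus a third placement of the same kind of change on the core. The two measured methyl steps bear on it directly, and both point the same way, so a lower number is expected for compound 4, of a size between the two measured steps, meaning a step of a 3.0-fold lower number from compound 1 to compound 4 (0.48 log units; beyond the scatter). On that basis compound 4 is estimated to give 3000 nM in this assay, with a range from 1200 nM to 8000 nM.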

Compound 4, concentration for 50% growth inhibition: 550 nM
Compound 4: middle estimate off by 5.5-fold (0.74 log units), on the high side; measured number below the stated range.
By their numbers in this assay, from the lowest: compound 4; then compound 2; then compound 3; then compound 1.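

In this assay, methyl in place of hydrogen on an aromatic carbon gives a 17-fold lower number from compound 1 to compound 4 (1.22 log units; beyond the scatter) when it stands two atoms from the ring nitrogen, and this step is large where the two earlier placements gave only modest ones. All three placements on the shared core run toward stronger inhibition of growth, so the direction of the change stayed the same, but this position shows that its size depends strongly on where the methyl sits. No evidence at hand explains why this position stands out from the other two.

The compounds shown leave open whether the large step is specific to methyl or would also appear with another group on this same carbon, such as an ethyl, a methoxy, a chlorine or an amine. They also leave open whether a second methyl, placed on the core alongside this one, would add to the step or leave the number in this assay where compound 4 already stands.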